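The source may hold more compounds than are shown below. What is called first, only, known or untested is meant among the compounds shown, and "the series" means these compounds.

Values in a functional assay on SMMC-7721 cells (Homo sapiens) for cytotoxicity, read by MTT assay, with a stated time of 24 h; a higher number here means a weaker inhibitor, a lower number a stronger inhibitor:

compound 1, `O=C1/C(=C/c2cccc(F)c2)CN(S(=O)(=O)c2ccc(O[N+](=O)[O-])cc2)C/C1=C\c1cccc(F)c1`: 15300 nM
compound 2, `O=C1/C(=C/c2cccc(F)c2)CN(S(=O)(=O)c2ccc(C(F)(F)F)cc2)C/C1=C\c1cccc(F)c1`: 4200 nM
compound 3, `O=C1/C(=C/c2cccc(F)c2)CN(S(=O)(=O)c2ccc(Br)cc2)C/C1=C\c1cccc(F)c1`: 11700 nM

For the measured compounds named here, compound 3 stands second highest of the three numbers: the step of a 1.3-fold lower number from compound 1 to compound 3 (0.12 log units; within the scatter) lies within the scatter, while the step of a 2.8-fold higher number from compound 2 to compound 3 (0.44 log units; beyond the scatter) is the only one that separates compound 3 from another compound. Compound 4, `CC(=O)Nc1ccc(S(=O)(=O)N2C/C(=C\c3cccc(F)c3)C(=O)/C(=C/c3cccc(F)c3)C2)cc1`, differs from compound 3 by acetamido in place of bromo on an aromatic carbon. Going by the values given here, no measured step involves an acetamido group, so the three exchanges at the same place are the only guide; the largest of them, a 3.6-fold lower number from compound 1 to compound 2 (0.56 log units; beyond the scatter), is modest, and the others are smaller. A step of comparable or smaller size is therefore expected here, direction uncertain, most likely not beyond the scatter: a 1.2-fold higher number from compound 3 to compound 4 (0.08 log units; within the scatter). Compound 4 is estimated at 14000 nM, with a range of 5000 nM to 40000 nM.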

Compound 4, half-maximal inhibitory concentration: 10300 nM
Compound 4: middle estimate off by 1.4-fold (0.13 log units), on the high side, and the stated range covers the measured number.
By their numbers in this assay, from the lowest: compound 2; then compounds 4, 3 and 1 (each within the scatter of the next).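

Acetamido brings in a hydrogen-bond donor and a hydrogen-bond acceptor that bromo lacks, yet a 1.1-fold lower number from compound 3 to compound 4 (0.06 log units; within the scatter) lies within the scatter, as does a 1.5-fold lower number from compound 1 to compound 4 (0.17 log units; within the scatter) against nitrooxy. Bromo, nitrooxy and acetamido therefore sit within the scatter of each other at this aromatic carbon, and only compound 2 departs from them, shown here by a 2.5-fold higher number from compound 2 to compound 4 (0.39 log units; beyond the scatter) for trifluoromethyl. No measurement bears on why trifluoromethyl alone stands apart. As far as these compounds go, whether an amine, a carboxylic acid or a longer chain at this place would join the three-group cluster or follow trifluoromethyl remains open.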